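The source may report more compounds than this note shows. Statements on the series, on what has been measured and on what is new or still open speak of the compounds shown alone.

Of the compounds shown here, three built on a shared core have been tested in a functional assay on MCF7 cells (Homo sapiens) for cytotoxicity, read by MTT assay, with a stated time of 72 h; a lower number here means a stronger inhibitor, a higher number a weaker inhibitor: compound 1 `COc1cccc(/C=C2\CCC/C(=C\c3ccc(Cl)cc3)C2=O)c1OC` gives 10300 nM, compound 2 `COc1cccc(/C=C2\CCC/C(=C\c3ccccc3Br)C2=O)c1OC` gives 9700 nM, and compound 3 `COc1cccc(/C=C2\CCC/C(=C\c3cccc(OC)c3OC)C2=O)c1` gives 5900 nM. Compound 1 stands within the scatter of both of the others, and these numbers set no order among the three.

Compound 4 `COc1cccc(/C=C2\CCC/C(=C\c3cccc(O)c3)C2=O)c1OC` has not yet been measured. It differs from compound 1 in one place, on a double-bonded chain carbon bound to a double-bonded ring carbon: 3-hydroxyphenyl in place of 4-chlorophenyl on a double-bonded chain carbon bound to a double-bonded ring carbon. All three measured steps were made at this same place. They are a 1.1-fold lower number from compound 1 to compound 2 (0.03 log units; within the scatter), a 1.7-fold lower number from compound 1 to compound 3 (0.24 log units; within the scatter) and a 1.6-fold lower number from compound 2 to compound 3 (0.22 log units; within the scatter), and each lies within the scatter. Of the three, the step to compound 3 bears most closely, as compound 3 carries 3-methoxyphenyl at this place. For the measured compounds named here, no measured compound carries 3-hydroxyphenyl, and the range given here is therefore kept wide.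

As far as these compounds go, on this evidence, no change beyond the scatter is expected in this assay, and the direction remains open. The estimated step is a 1.6-fold lower number from compound 1 to compound 4 (0.20 log units; within the scatter). For compound 4 the estimated value is 6500 nM, with an expected range from 2500 nM to 15000 nM.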

Compound 4, half-maximal inhibitory concentration: 8800 nM
The estimate for compound 4 lay 1.4-fold (0.13 log units) below the measured number; measured number inside the range.
By their numbers in this assay, from the lowest: compounds 3, 4, 2 and 1 (each within the scatter of the next).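

In this assay, 3-hydroxyphenyl at this place, on a double-bonded chain carbon bound to a double-bonded ring carbon, gives a 1.2-fold lower number from compound 1 to compound 4 (0.07 log units; within the scatter) and a 1.1-fold lower number from compound 2 to compound 4 (0.04 log units; within the scatter) and so adds a hydrogen-bond donor, which 4-chlorophenyl lacks, with no change beyond the scatter. The step of a 1.5-fold higher number from compound 3 to compound 4 (0.17 log units; within the scatter) is the only one shown that has hydrogen in place of methyl on an oxygen on an aromatic ring, and this exchange, too, stays within the scatter, so at this place neither the halogen-bearing groups, the methoxy group nor the hydroxy group sets any order among the four compounds. Nothing given here bears on why the numbers stay so close.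

Every group shown at this place is a substituted phenyl, and all four compounds lie within the scatter of one another, so it stays open whether any change here can move the number beyond the scatter. An aminophenyl or a carboxyphenyl group at this place, or a longer chain in place of the phenyl ring, could test this, and the compounds shown give no hint of what either would do.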